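This account rests on a few compounds, and the source may have more. Where it says the series, first, only, none or still open, it means among the compounds named here.

Working notes on the aromatic ester series. The shared core carries an ester whose aromatic part varies. Compound 2 `CC1=CC[C@H](C(C)C)c2cc(C)c(OC(=O)c3ccc(Cl)cc3)cc21` bears a 4-chlorophenyl group on the carbonyl carbon; compound 1 `CC1=CC[C@H](C(C)C)c2cc(C)c(OC(=O)c3ccc(C(F)(F)F)cc3)cc21` is the same with a trifluoromethyl in place of the chloro; compound 3 `CC1=CC[C@H](C(C)C)c2cc(C)c(OC(=O)c3cccc(Cl)c3)cc21` rearranges the same atoms to a 3-chlorophenyl group; compound 4 `CC1=CC[C@H](C(C)C)c2cc(C)c(OC(=O)c3cccc(C(F)(F)F)c3)cc21` is not yet measured.

In a functional assay on U-251 cells (Homo sapiens) for antiproliferative activity, read by sulforhodamine B assay, with a stated time of 48 h, tested at 50 uM (on this read-out higher numbers stand for more inhibition at the one concentration tested (going by the name of the read-out) and lower numbers for less inhibition), compound 2 gives 25.6%. In this assay compound 1 gives 14.7%, the step of a number 10.9 percentage points lower from compound 2 to compound 1 (beyond the scatter) being the change (trifluoromethyl in place of chloro on an aromatic carbon). Compound 3 gives 0.9% in this assay; its difference from compound 2 is 3-chlorophenyl in place of 4-chlorophenyl on a carbonyl carbon, and the step is a number 24.7 percentage points lower from compound 2 to compound 3 (beyond the scatter). Compound 3 stands lowest of the three, both other compounds lying beyond the scatter from it.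

Compound 4 differs from compound 3 by trifluoromethyl in place of chloro on an aromatic carbon. This is the same kind of change as that from compound 2 to compound 1, not the same: there the group stands para to a large group, here meta to a large group. That earlier change lowered the number modestly. Starting from compound 3, whose value 0.9% already sits close to the bottom of the read-out, little room remains, so the expected step of a number 1.1 percentage points higher from compound 3 to compound 4 (within the scatter) is smaller than the earlier one. Compound 4 is expected to give about 2%, between -8% and 14%.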

Compound 4, a percentage reported as inhibition, at one concentration (the size of the read-out at that concentration, not a potency): 29.3%
Compound 4: middle estimate off by 27.3 percentage points, on the low side; the measured number lies above the stated range.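

In this assay, trifluoromethyl in place of chloro on an aromatic carbon, here meta to a large group, gives a number 28.4 percentage points higher from compound 3 to compound 4 (beyond the scatter). The change therefore does not carry over from one core to the other in either size or direction, so the step seen on one aromatic ester cannot serve as an estimate for its counterpart on the other: the same change on two cores in this assay, a number 10.9 percentage points lower (beyond the scatter) from compound 2 to compound 1 and a number 28.4 percentage points higher (beyond the scatter) from compound 3 to compound 4, 39.3 percentage points apart, beyond the scatter of two such steps

This shows that the outcome of the exchange depends on the compound that receives it, but it rests on only two pairs, each read at a single concentration in one cell line, and it does not show why the two steps part or whether the same split would appear with other pairs in the series.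

The compounds shown leave open how a nitrile, a methoxy group, an amine or a carboxylic acid would behave in the place of chloro and trifluoromethyl on the same aromatic ring, and whether any of these would also give steps that differ between the two arrangements. They also leave open whether the values at the one concentration tested would hold their order across a range of concentrations.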